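This account rests on a few compounds, and the source may have more. Where it says the series, first, only, none or still open, it means among the compounds named here.

Measured so far:
- Compound 1, `COc1ccc(-c2cnc(NC(=O)CCCCCCNC(=O)C(O)(O)C(F)(F)F)s2)cc1`: 13000 nM
- Compound 2, `COc1ccc2sc(NC(=O)CCCCCCNC(=O)C(O)(O)C(F)(F)F)nc2c1`: 8900 nM
- Compound 3, `O=C(CCCCCCNC(=O)C(O)(O)C(F)(F)F)Nc1ccc(Br)cc1`: 11000 nM

These three compounds were tested in an assay on isolated protein for inhibition of histone deacetylase 8 (Homo sapiens), read by chemiluminescence, with a stated time of 3 h; on this read-out lower numbers stand for stronger inhibition and higher numbers for weaker inhibition. In this assay compound 1 gives 13000 nM, compound 2 gives 8900 nM and compound 3 gives 11000 nM. The three numbers lie so close together that the gap from compound 1 to compound 3, and likewise the gap from compound 1 to compound 2, falls within the usual scatter of repeated measurements, so compound 1 cannot be told apart from either of its two companions on these data.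

The next compound, compound 4, `O=C(CCCCCCNC(=O)C(O)(O)C(F)(F)F)Nc1ncc(-c2ccc(O)cc2)s1`, is not yet measured. It differs from compound 1 in one place: hydrogen in place of methyl on an oxygen on an aromatic ring. The long chain, the two amide groups and the shared core are kept unchanged.

Going by the values given here, no measured pair shows the effect of exactly this change, so there is nothing to go on beyond the three numbers themselves. The step from compound 1 to compound 4 in this assay is expected to be small, a 1.1-fold lower number from compound 1 to compound 4 (0.03 log units; within the scatter), in no clear direction and not beyond the scatter. For compound 4 the estimate is therefore 12000 nM, with a range from 5000 nM to 30000 nM.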

Compound 4, half-maximal inhibitory concentration: 30000 nM
The estimate for compound 4 lay 2.5-fold (0.40 log units) below the measured number; the measured number falls inside the stated range.
By their numbers in this assay, from the lowest: compounds 2, 3 and 1 (each within the scatter of the next); then compound 4.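

In this assay, going from 4-methoxyphenyl to 4-hydroxyphenyl gives a 2.3-fold higher number from compound 1 to compound 4 (0.36 log units; beyond the scatter). This step lies beyond the usual scatter of repeated measurements, and inhibition is weaker with hydrogen in place of methyl on this oxygen. The earlier compounds shown here could not show this, as they differ from each other in more than one place and offer no step that can be read. No evidence is at hand on what lies behind this step.

As far as these compounds go, it remains open whether an ethoxy group, an amine or a fluorine at this place on the aromatic ring would give a number closer to that of compound 1 or of compound 4. From the compounds shown here alone, it is also open whether the same change from methoxy to hydroxy on compound 2 would move its number in the same direction.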